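Series notes: a core with amide and ring-nitrogen substituents

The source may hold more compounds than are shown below. What is called first, only, known or untested is meant among the compounds shown, and "the series" means these compounds.

Measured compounds:
compound 1, `NC(=O)c1c(NC(=O)c2ccccc2Cl)sc2c1CCN(Cc1cc(Cl)cc(Cl)c1)C2` — in a functional assay on HeLa cells (Homo sapiens) for antiproliferative activity, with a stated time of 24 h (on this read-out higher numbers stand for weaker inhibition and lower numbers for stronger inhibition), compound 1 gives 19600 nM.
compound 2, `NC(=O)c1c(NC(=O)c2ccc(C(F)(F)F)cc2)sc2c1CCN(Cc1ccc(Cl)cc1Cl)C2` — in this assay compound 2 gives only a limit, > 50000 nM.

Among the compounds with values here, compound 1 holds the only numerical value in this assay; the other result recorded is a limit, (the limit of > 50000 nM in this assay, at which 1 of the 2 values shown sits), and so no measured step between two numbers can be drawn from the present data.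

Compound 3, `CSc1ccccc1NC(=S)N1CCc2c(sc(NC(=O)c3ccccc3Cl)c2C(N)=O)C1`, is not yet measured. It differs from compound 1 in one place: a group of 11 heavy atoms (8 carbon, 1 nitrogen, 2 sulfur; one six-membered aromatic ring of carbon only) in place of a group of 9 heavy atoms (7 carbon, 2 chlorine; one six-membered aromatic ring of carbon only), on an amine nitrogen in a ring. Within the data shown here, no measured pair shares this kind of change, so its size has no precedent here. Given that compound 1 sits at a weak level in this assay and the one other member of the series reached only a limit, the change is expected to move the value by a modest step in either direction, likely not beyond the scatter, with some chance of a limit. For compound 3 the estimated outcome is 22000 nM, within a range from 6000 nM to 80000 nM, which is an expected step of a 1.1-fold higher number from compound 1 to compound 3 (0.05 log units; within the scatter).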

Compound 3, half-maximal inhibitory concentration: 43600 nM
Compound 3: the middle estimate sits 2.0-fold (0.30 log units) below what was measured; the measured number falls inside the stated range.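

Within the data shown here, this is the first measured step: on an amine nitrogen in a ring, replacing 3,5-dichlorobenzyl with the group of 11 heavy atoms gives a 2.2-fold higher number from compound 1 to compound 3 (0.35 log units; beyond the scatter). This position therefore responds to change in this assay, although the shift toward weaker inhibition is modest and compound 3 still gives a number, 43600 nM, rather than a limit. The entering group carries 1 hydrogen-bond donor, 2 hydrogen-bond acceptors and 1 double bond outside aromatic rings, none of which the leaving group has, but nothing measured here bears on the cause of the step.

A single step leaves open how an unsubstituted benzyl, a methyl or a urea with oxygen in place of the doubly bonded sulfur would read on the same nitrogen, so the parts of the entering group cannot yet be separated. Among these compounds, compound 2 remains a limit and differs from compound 1 in more than one place, so no step involving it can be read.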